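The source may hold more compounds than are shown below. What is called first, only, known or untested is meant among the compounds shown, and "the series" means these compounds.

Within the data shown here, in a functional assay on Hep 3B2 cells (Homo sapiens) for cytotoxicity, read by MTT assay, with a stated time of 6 days (a lower number here means a stronger inhibitor, a higher number a weaker inhibitor), only one compound of this small set yields a number. Compound 1 `Cc1ccc2c(c1)OCC(=O)N2Cc1cn(Cc2ccccc2)nn1` sits at the limit of this assay, at > 100000 nM. Compound 2 `Cc1cc2c(cc1Cl)N(Cc1cn(Cc3ccccc3)nn1)C(=O)CO2` likewise reaches only the limit, > 100000 nM. Among the measured compounds shown here, compound 3 `O=C1COc2ccc(Cl)cc2N1Cc1cn(Cc2ccccc2)nn1` is the sole member with a read value in this assay, 55500 nM. The other two values shown are limits, so compound 3 stands alone as the one readable point of the series. The step that the two limits leave unreadable from compound 1 to compound 2 cannot be sized, and the step of an at least 1.8-fold lower number from compound 2 to compound 3 (0.25 log units; that floor lies within the scatter) rests on one limit and one number.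

Compound 4 `COc1ccc2c(c1)N(Cc1cn(Cc3ccccc3)nn1)C(=O)CO2` differs from compound 3 by methoxy in place of chloro on an aromatic carbon. For the measured compounds named here, neither measured step touches this change directly; one leaves both ends at the limit, the other turns a limit into the only readable number. With 2 of 3 values sitting at the limit of > 100000 nM in this assay, at which 2 of the 3 values shown sit, the expectation for compound 4 is a value near or past that limit, and the step of a 1.8-fold higher number from compound 3 to compound 4 (0.26 log units; within the scatter) is estimated to run toward a weaker compound. Compound 4 is accordingly estimated at 100000 nM, within 40000 nM to 300000 nM.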

Compound 4, half-maximal inhibitory concentration: > 100000 nM
Compound 4 gave a limit, no number (the forecaster's own chance of this, stated with the estimate: 55%); the middle value sits exactly at the limit.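

In this assay, methoxy in place of chloro on this aromatic carbon gives an at least 1.8-fold higher number from compound 3 to compound 4 (0.25 log units; that floor lies within the scatter). This is the first change shown at this position that starts from the one readable number, but compound 4 gives only a limit, > 100000 nM, so the true size of the step stays unknown and its printed floor does not go beyond the scatter. Compound 3 therefore remains the only compound with a number, and methoxy does not provide a second readable point: the limit of > 100000 nM in this assay, at which 3 of the 4 values shown sit.

From the compounds shown here alone, whether another group here, such as fluoro, an amine or a carboxylic acid, would give a second number remains open. With a single number in the set, the limits leave no order among compound 1, compound 2 and compound 4, and no trend at this position can yet be drawn.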